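The compounds below may be only part of what the source reports. "The series", "measured", "known", "first", "only" and "open" are said of these compounds alone.

Of the compounds shown here, two have so far been measured in a functional assay on HL-60 cells (Homo sapiens) for inhibition, read by MTT assay, with a stated time of 48 h, tested at 10 uM; a lower number here means less inhibition of growth, a higher number more inhibition of growth at the concentration tested. Compound 1 `Cc1cc(=O)c2c(O)c(CN(C(C)C)C(C)C)c(O)c([C@H]3CCN(C)C[C@H]3O)c2o1` gives 21%, and compound 2 `Cc1oc2c([C@H]3CCN(C)C[C@H]3O)c(O)cc(O)c2c(=O)c1C(O)c1cccc(Cl)c1` gives 22%. These two numbers lie within the scatter of each other, so compound 2 stands level with compound 1, and neither can be ranked above the other.

The next compound, compound 3 `Cc1oc2c([C@H]3CCN(C)C[C@H]3O)c(O)cc(O)c2c(=O)c1C(O)c1c(F)cccc1Cl`, differs from compound 2 in one place: it has 2-chloro-6-fluorophenyl in place of 3-chlorophenyl on a saturated chain carbon bound to an aromatic carbon and an oxygen on a saturated carbon. The rest of the structure stays the same. Going by the values given here, no pair of measured compounds differs in a single place, so the data give no direct guide to the size of such a change. The expectation therefore starts from compound 2 at 22%. The expected result is a small upward move that stays within the scatter, written as a number 3 percentage points higher from compound 2 to compound 3 (within the scatter). For compound 3 the estimated value is 25%, with an expected range from 12% to 40%.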

Compound 3, percent growth inhibition at one concentration: 49%
Estimate against measurement, compound 3: 24 percentage points below; the whole stated range lies below it.
By their numbers in this assay, from the lowest: compounds 1 and 2 (each within the scatter of the next); then compound 3.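

In this assay, going by these compounds alone, the aryl group on a saturated chain carbon bound to an aromatic carbon and an oxygen on a saturated carbon gives the first single change that can be read: 2-chloro-6-fluorophenyl in place of 3-chlorophenyl gives a number 27 percentage points higher from compound 2 to compound 3 (beyond the scatter). This shows that the aryl group at this position can change growth inhibition beyond the scatter while the rest of the structure stays the same. The data shown offer no measurement that bears on the reason for this step.

The change alters the chlorine's location on the ring and adds a fluorine in one step, so the compounds shown cannot separate these two differences, and it remains open whether 2-chlorophenyl, 2-fluorophenyl, 2,6-dichlorophenyl or unsubstituted phenyl would behave like either compound. From the compounds shown here alone, it also remains open whether the step holds with a pyridyl ring at this position or with an amine in place of the hydroxy group on the same carbon, and, as each compound is read at one concentration, whether it would carry over to a full concentration-response comparison.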